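The source may hold more compounds than are shown below. What is called first, only, known or untested is meant among the compounds shown, and "the series" means these compounds.

Measured compounds:
- compound 1, `COc1ccc(/C=C/C(=O)Nc2cc(C(=O)c3cc(OC)c(OC)c(OC)c3)cc(OC)c2OC)cc1` — 4800 nM
- compound 2, `COc1cccc(/C=C/C(=O)Nc2cc(C(=O)c3cc(OC)c(OC)c(OC)c3)cc(OC)c2OC)c1` — 10700 nM
- compound 3, `COc1cc(C(=O)c2cc(OC)c(OC)c(OC)c2)cc(NC(=O)/C=C/c2ccc(F)cc2)c1OC` — 3100 nM

All three share one core and differ only in the aryl group on the double-bonded chain. In a functional assay on COLO 205 cells (Homo sapiens) for cytotoxicity, read by MTT assay, with a stated time of 72 h (on this read-out higher numbers stand for weaker inhibition and lower numbers for stronger inhibition), compound 3 gives the lowest number of the three, yet its separation from compound 1 is a 1.5-fold lower number from compound 1 to compound 3 (0.19 log units; within the scatter), within the scatter, so the two cannot be ordered; only a 3.5-fold lower number from compound 2 to compound 3 (0.54 log units; beyond the scatter) stands clearly apart. Compound 4, `COc1cc(C(=O)c2cc(OC)c(OC)c(OC)c2)cc(NC(=O)/C=C/c2ccc(C(F)(F)F)cc2)c1OC`, is the next member: trifluoromethyl in place of fluoro on an aromatic carbon.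

Among the compounds with values here, no measured pair here varies the size of a single substituent at this position; the steps that bear on it only exchange one small group for another at the same place (a 1.5-fold lower number from compound 1 to compound 3 (0.19 log units; within the scatter)) or move the methoxy to another ring position (a 2.2-fold higher number from compound 1 to compound 2 (0.35 log units; beyond the scatter)), and both are small to modest. Substituent exchange in this series has so far moved this assay only by small to modest steps, so for compound 4 the step is expected to be small, a 1.1-fold higher number from compound 3 to compound 4 (0.05 log units; within the scatter), with no clear direction. Compound 4 is therefore estimated at 3500 nM, in the range 1400 nM to 9000 nM.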

Compound 4, half-maximal inhibitory concentration: 2500 nM
Compound 4: middle estimate off by 1.4-fold (0.15 log units), on the high side; the measured number falls inside the stated range.
By their numbers in this assay, from the lowest: compounds 4, 3 and 1 (each within the scatter of the next); then compound 2.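

In this assay, within the data shown here, the fluoro to trifluoromethyl exchange is the first step to change the size of the group at this place, from 1 heavy atom to 4, and the number stays within the scatter (a 1.2-fold lower number from compound 3 to compound 4 (0.09 log units; within the scatter)). The exchange of methoxy for trifluoromethyl at the same carbon is also within the scatter (a 1.9-fold lower number from compound 1 to compound 4 (0.28 log units; within the scatter)), so compound 1, compound 3 and compound 4 cannot be ordered, while the step from the 3-methoxyphenyl member is beyond it (a 4.3-fold lower number from compound 2 to compound 4 (0.63 log units; beyond the scatter)). Nothing measured here accounts for these numbers.

From the compounds shown here alone, whether an amine, a carboxylic acid or a longer chain at this carbon would keep the number in the same range remains open. Also open, going by these compounds, is whether the gap of compound 2 belongs to the methoxy group at its ring position or would recur with a 3-fluorophenyl group.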